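A Methyl Added to the Sec-Butyl Chain

A few compounds are considered here, and "the series" means these few. Any claim that something is new, unique, unknown or untested is made for them only; others in the source may bear on it.

In a functional assay on LNCaP cells (Homo sapiens) for inhibition, read by WST assay, with a stated time of 3 days (on this read-out lower numbers stand for stronger inhibition and higher numbers for weaker inhibition), compound 2 `CCC(C)n1ccnc1/C=C/C(=O)/C=C/c1coc2ccccc2c1=O` gives 1300 nM and compound 1 `CCCCCn1ccnc1/C=C/C(=O)/C=C/c1coc2ccccc2c1=O` gives 1800 nM so that the two stand within the scatter of each other. Compound 3 `CCCC(C)n1ccnc1/C=C/C(=O)/C=C/c1coc2ccccc2c1=O` differs from compound 2 by methyl in place of hydrogen on a saturated chain carbon, three bonds along the chain from an aromatic nitrogen as methyl in place of hydrogen on a saturated chain carbon, three bonds along the chain from an aromatic nitrogen, which reads sec-butyl to 1-methylbutyl. For the measured compounds named here, the one measured step on this chain, a 1.4-fold lower number from compound 1 to compound 2 (0.14 log units; within the scatter) for sec-butyl in place of pentyl, stays small, so no step beyond the scatter is expected in this assay here. The expected step is a 1.2-fold higher number from compound 2 to compound 3 (0.06 log units; within the scatter) and nothing larger is estimated. Compound 3 is expected at 1500 nM within a range of 750 nM to 3000 nM in this read-out.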

Compound 3, half-maximal inhibitory concentration: 3900 nM
Estimate against measurement, compound 3: 2.6-fold (0.41 log units) below, and the stated range ends below it.
By their numbers in this assay, from the lowest: compounds 2 and 1 (each within the scatter of the next); then compound 3.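

In this assay, this chain position proves sensitive where the earlier pair showed no step beyond the scatter: methyl in place of hydrogen on a saturated chain carbon, three bonds along the chain from an aromatic nitrogen, gives a 3.0-fold higher number from compound 2 to compound 3 (0.48 log units; beyond the scatter). The change also separates 1-methylbutyl from pentyl, with a 2.2-fold higher number from compound 1 to compound 3 (0.34 log units; beyond the scatter). Nothing available accounts for these steps. On these data alone, whether a longer branched chain such as 1-methylpentyl would raise the number further stays open, as does how a chain ending in an amine or a carboxylic acid would read.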